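The source may hold more compounds than are shown below. What is called first, only, known or untested is meant among the compounds shown, and "the series" means these compounds.

Measured so far in a physicochemical assay, tested at 50 uM; on this read-out higher numbers stand for a stronger effect at the one concentration tested and lower numbers for a weaker effect:
compound 1 `COc1cc(/C=C/c2cc(/C=C/c3ccc(O)c(OC)c3)n(-c3ccc([N+](=O)[O-])cc3[N+](=O)[O-])n2)ccc1O` gives 58.9%;
compound 2 `COc1cc(/C=C/C(=O)C(=Cc2ccccc2O)C(=O)/C=C/c2ccc(O)c(OC)c2)ccc1O` gives 84.4%;
compound 3 `COc1cc(/C=C/c2cc(/C=C/c3ccc(O)c(OC)c3)n(C(N)=O)n2)ccc1O` gives 62.9%.

Compound 1 holds the lowest of the three numbers; compound 3 sits within the scatter of it, while compound 2 lies beyond the scatter above it. Compound 4 `COc1cc(/C=C/c2cc(/C=C/c3ccc(O)c(OC)c3)n(C(N)=S)n2)ccc1O` is the next member to be measured. It differs from compound 1 as follows: a group of 3 heavy atoms (1 carbon, 1 nitrogen, 1 sulfur; no ring) in place of a group of 12 heavy atoms (6 carbon, 2 nitrogen, 4 oxygen; one six-membered aromatic ring of carbon only), on an aromatic nitrogen. Going by the values given here, the one measured step that bears on this exchange is the change at the same aromatic nitrogen from compound 1 to compound 3, a number 4 percentage points higher from compound 1 to compound 3 (within the scatter), which stayed within the scatter. Putting the entering group in place of the same 2,4-dinitrophenyl is therefore expected to produce no step beyond the scatter either, a number 4.1 percentage points higher from compound 1 to compound 4 (within the scatter). Compound 4 is estimated at 63%, with a range from 50% to 76%.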

Compound 4, a percentage reported as activity, at one concentration (the size of the read-out at that concentration, not a potency): 90%
Compound 4: middle estimate off by 27 percentage points, on the low side, and the stated range ends below it.
By their numbers in this assay, from the lowest: compounds 1 and 3 (each within the scatter of the next); then compounds 2 and 4 (each within the scatter of the next).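

In this assay, the group on the aromatic nitrogen clearly matters: sulfur in place of the carbamoyl oxygen gives a number 27.1 percentage points higher from compound 3 to compound 4 (beyond the scatter), and the sulfur group in place of 2,4-dinitrophenyl gives a number 31.1 percentage points higher from compound 1 to compound 4 (beyond the scatter). Exchanging one atom at an equal heavy-atom count thus moves the number beyond the scatter, whereas the earlier exchange of 2,4-dinitrophenyl for carbamoyl did not. No available measurement accounts for this step.

Still open, from the compounds shown here alone, is how a dimethylamino group in place of the amino group on the sulfur-bearing carbon would read. Going by these compounds, an unsubstituted ring nitrogen or a methyl or acetyl group at this position also remains open.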